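The compounds below may be only part of what the source reports. "The series", "measured", "known", "first", "only" and "open" are said of these compounds alone.

Compound 1, `CCCc1cc(NC2CCC2)c2cc(NC(=O)/C=C/c3ccc(C(F)(F)F)cc3)ccc2n1`, gives 18 nM in an assay on isolated protein for displacement of a labelled ligand from melanin-concentrating hormone receptor 1 (Homo sapiens); a higher number here means a weaker inhibitor, a lower number a stronger inhibitor.
Compound 2, `Nc1cc(C2CCC2)nc2ccc(NC(=O)/C=C/c3ccc(C(F)(F)F)cc3)cc12`, gives 2 nM in this assay.
Compound 3, `CCCCc1ccc(/C=C/C(=O)Nc2ccc3nc(CCC)cc(N)c3c2)cc1`, gives 45 nM in this assay.

Among these three numbers compound 1 stands second highest. Its nearest neighbour is compound 3, whose number is higher by a margin beyond the usual scatter, and the furthest is compound 2, whose number is lower by a margin well beyond it. None of the three pairs differs in only one place, so no single-step comparison is available here.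

Compound 4, `CCCc1cc(NC)c2cc(NC(=O)/C=C/c3ccc(C(F)(F)F)cc3)ccc2n1`, is not yet measured. It departs from compound 1 by methyl in place of cyclobutyl on a nitrogen on an aromatic ring. The anilino-type nitrogen keeps its hydrogen; only the substituent on it shrinks from a small carbocycle to the smallest alkyl group.

Among the compounds with values here, with no measured pair that isolates this change, the expectation rests on the size of the group removed. A step of moderate size is expected, most likely towards a higher number, but it may also stay within the scatter; the expected change from compound 1 to compound 4 is a 1.9-fold higher number from compound 1 to compound 4 (0.29 log units; within the scatter). For compound 4 the estimate in this assay is 35 nM, with a range from 10 nM to 120 nM.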

Compound 4, half-maximal inhibitory concentration: 1.5 nM
Estimate against measurement, compound 4: 23-fold (1.37 log units) above, outside the stated range (below it).
By their numbers in this assay, from the lowest: compounds 4 and 2 (each within the scatter of the next); then compound 1; then compound 3.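

In this assay, within the data shown here, this is the first comparison that changes only one place, and it shows that the group on this nitrogen has a strong bearing on the number: going from cyclobutylamino to methylamino gives a 12-fold lower number from compound 1 to compound 4 (1.08 log units; beyond the scatter). The step is large and beyond the scatter, and it runs towards the lower number even though the four-membered carbocycle gives way to the smallest alkyl group, so at this position, with the rest of compound 1 held fixed, the cyclobutyl group is not needed for a low number. No measurement at hand accounts for this step, which therefore stands as an observation without an established cause.

With only cyclobutyl and methyl compared on this nitrogen, the compounds shown leave open how the number changes for intermediate groups such as ethyl or cyclopropyl, and whether it moves steadily with size or turns on something specific to the cyclobutyl group. They also leave open whether a step of this size would recur if the propyl chain on the shared core were replaced by another group, such as a butyl chain.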